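The source may hold more compounds than are shown below. What is called first, only, known or untested is meant among the compounds shown, and "the series" means these compounds.

Compound 1 `Cc1ccc(CNC(=O)c2cccc(C(C)Oc3cccnc3Nc3ncccn3)c2)cc1` — in a functional assay on NCI-H3122 cells (Homo sapiens) for antiproliferative activity, read by MTT assay, with a stated time of 48 h (on this read-out higher numbers stand for weaker inhibition and lower numbers for stronger inhibition), compound 1 gives > 100000 nM, which is a limit of the assay rather than a number.
Compound 2 `COc1cc(CNC(=O)c2cccc(C(C)Oc3ccnc(Nc4cnn(C)c4)c3)c2)cc(OC)c1OC` — in this assay compound 2 gives 29000 nM.
Compound 3 `Cc1ccc(CNC(=O)c2cccc(C(C)Oc3ccnc(Nc4cn(C)nc4C)c3)c2)cc1` — in this assay compound 3 gives 13400 nM.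

Compound 3 therefore holds the lowest of the two numbers obtained so far; compound 2, its nearest neighbour, sits higher by a gap that lies beyond the usual scatter of repeated measurements. Compound 4 `COc1cc(Nc2cc(OC(C)c3cccc(C(=O)NCc4ccc(C)cc4)c3)ccn2)cc(OC)c1OC` differs from compound 3 in one place: 3,4,5-trimethoxyphenyl in place of 1,3-dimethyl-1H-pyrazol-4-yl on a nitrogen on an aromatic ring. Going by the values given here, no two measured compounds differ by this change alone, so no measured step shows what it does; compound 2 carries a trimethoxy-bearing group on the other side of the shared core, and its value stands above that of compound 3, but that is a different position and not the same change. Without a matching step, compound 4 is expected to land close to compound 3, with at most a modest move toward weaker inhibition, and the step from compound 3 to compound 4 is estimated as a 1.5-fold higher number from compound 3 to compound 4 (0.17 log units; within the scatter). Compound 4 is thus expected to give about 20000 nM, in the range 6000 nM to 80000 nM.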

Compound 4, half-maximal inhibitory concentration: 7800 nM
Compound 4: the middle estimate sits 2.6-fold (0.41 log units) above what was measured; the measured number falls inside the stated range.
By their numbers in this assay, from the lowest: compounds 4 and 3 (each within the scatter of the next); then compound 2. At a limit, above all of these: compound 1.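

In this assay, the first step measured on this nitrogen on an aromatic ring is a 1.7-fold lower number from compound 3 to compound 4 (0.24 log units; within the scatter), which lies within the scatter. On this read-out, 3,4,5-trimethoxyphenyl, with 12 heavy atoms on a six-membered aromatic ring of carbon only, therefore cannot be told apart from 1,3-dimethyl-1H-pyrazol-4-yl, with 7 heavy atoms on a five-membered aromatic ring, and the larger group brings no loss that this assay can detect. Nothing measured here accounts for this step.

The compounds shown leave open whether a plain phenyl, with no methoxy groups, or a piperidine in this place would give a similar number. They also leave open how the group on the amide nitrogen contributes, since compound 2 differs from compound 3 and compound 4 in more than one place.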